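A few compounds are considered here, and "the series" means these few. Any claim that something is new, unique, unknown or untested is made for them only; others in the source may bear on it.

Measured so far in a functional assay on A549 cells (Homo sapiens), read by MTT assay, with a stated time of 72 h; a higher number here means a weaker inhibitor, a lower number a stronger inhibitor:
compound 1 `CN(C)c1ncnc2c1c(-c1cc3ccccc3o1)cn2[C@@H]1O[C@H](CO)[C@@H](O)[C@H]1O` gives > 20000 nM, a limit of the assay.
compound 2 `C#Cc1cn([C@@H]2O[C@H](CO)[C@@H](O)[C@H]2O)c2ncnc(N(C)C)c12` gives 390 nM.
compound 3 `CN(C)c1ncnc2c1c(-c1ccoc1)cn2[C@@H]1O[C@H](CO)[C@@H](O)[C@H]1O` gives > 20000 nM, a limit of the assay.

Within the data shown here, compound 2 stands as the only numeric value among the three; the other two values sit at a limit of this assay (the limit of > 20000 nM in this assay, at which 2 of the 3 values shown sit). The step of an at least 51-fold lower number from compound 1 to compound 2 (1.70 log units; beyond the scatter) and the step of an at least 51-fold higher number from compound 2 to compound 3 (1.70 log units; beyond the scatter) are both large; the step that the two limits leave unreadable from compound 1 to compound 3 cannot be read because both of its ends sit at the limit. All three steps change the group on the aromatic carbon, and compound 4 `C#Cc1cn([C@@H]2O[C@H](CO)[C@@H](O)[C@H]2O)c2ncnc(NC)c12` keeps the ethynyl group of compound 2 unchanged there. Compound 4 differs from compound 2 by hydrogen in place of methyl on a nitrogen on an aromatic ring. Among the measured compounds shown here, no measured step touches the nitrogen on the aromatic ring, so none of the three steps bears on this change; the large steps seen concern only the aromatic carbon substituent. For the measured compounds named here, with no comparable step to draw on, the expectation for this assay is a step of no clear direction, most likely within the scatter, but the range is kept wide. The expected step from compound 2 to compound 4 is a 1.1-fold lower number from compound 2 to compound 4 (0.05 log units; within the scatter). Compound 4 is therefore estimated at 350 nM, with the range 70 nM to 2500 nM.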

Compound 4, half-maximal inhibitory concentration: > 20000 nM
Compound 4: no number, only a limit; the forecaster's own chance of this, stated with the estimate: 5%; middle value at least 57-fold (1.75 log units) away from the limit.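

In this assay, the change from dimethylamino to methylamino, hydrogen in place of methyl on a nitrogen on an aromatic ring, gives an at least 51-fold higher number from compound 2 to compound 4 (1.70 log units; beyond the scatter), so this nitrogen is a second place in the series where a single change costs the numeric read-out, and here the ethynyl group on the aromatic carbon stays in place. Compound 4 gives > 20000 nM, which is a limit and not a number, so the step has a lower bound and no measured size. Compound 2 remains the only compound with a number, and compound 4 joins the compounds at the ceiling: the limit of > 20000 nM in this assay, at which 3 of the 4 values shown sit.

The compounds shown hold only dimethylamino and methylamino on this nitrogen, so it remains open whether a larger group such as diethylamino, or an unsubstituted amine, would keep or lose the read-out. From the compounds shown here alone, it is also open whether methylamino would behave the same way with a group other than ethynyl on the aromatic carbon, such as a propynyl chain or a nitrile.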